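Replacing iodo with 4-cyanophenyl: expected cytotoxicity

The source may report more compounds than this note shows. Statements on the series, on what has been measured and on what is new or still open speak of the compounds shown alone.

Measured in an ADME assay on HEL cells (Homo sapiens) for cytotoxicity, with a stated time of 3 days; on this read-out lower numbers stand for higher toxicity in this test and higher numbers for lower toxicity in this test:
- compound 1, `Cc1cc(-c2ccccc2)cn2c(CSCCc3ccccc3)cnc12`, gives 31 ug/mL.
- compound 2, `Cc1cc(I)cn2c(CSCCc3ccccc3)cnc12`, gives only a limit of the assay, > 50 ug/mL.

Compound 2 thus stands at the limit of > 50 ug/mL in this assay, at which 1 of the 2 values shown sits, so no exact number for it is known. Going by the values given here, the only measured step is an at least 1.6-fold higher number from compound 1 to compound 2 (0.20 log units; that floor lies within the scatter), which lies within the usual scatter and cannot be read as a real difference.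

Compound 3, `Cc1cc(-c2ccc(C#N)cc2)cn2c(CSCCc3ccccc3)cnc12`, differs from compound 2 by 4-cyanophenyl in place of iodo on an aromatic carbon. This brings back an aromatic ring where compound 1 also carries one, so compound 1 is the closest guide. Compound 3 is therefore expected to give 30 ug/mL, within 12 ug/mL to 70 ug/mL. That corresponds to an expected at least 1.6-fold lower number from compound 2 to compound 3 (0.22 log units; that floor lies within the scatter), a somewhat lower number, although its true size stays uncertain because compound 2 sits at the limit of > 50 ug/mL in this assay, at which 1 of the 2 values shown sits.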

Compound 3, half-maximal cytotoxic concentration: 10.6 ug/mL
Compound 3: middle estimate off by 2.8-fold (0.45 log units), on the high side; measured number outside the range, below it.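

In this assay, 4-cyanophenyl in place of iodo on this aromatic carbon gives an at least 4.7-fold lower number from compound 2 to compound 3 (0.67 log units; beyond the scatter), so a change at this position can move the read-out beyond the scatter and towards higher toxicity in this test, which the earlier step could not show. Compound 2 has only a limit of the assay, so the true size of that step stays unknown: the limit of > 50 ug/mL in this assay, at which 1 of the 3 values shown sits.

The closer comparison is cyano in place of hydrogen on the phenyl ring, which gives a 2.9-fold lower number from compound 1 to compound 3 (0.47 log units; beyond the scatter), so an aromatic ring alone does not account for the lower number of compound 3.

On these data alone, it remains open whether this lower number is particular to the cyano group, or whether an amine, a methoxy group or a carboxylic acid at the same ring carbon would give a similar number. The compounds shown also leave open how cyano would behave at another carbon of that phenyl ring.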